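Furan in place of dimethoxyphenyl at the dienone end

The compounds below may be only part of what the source reports. "The series", "measured", "known", "first", "only" and "open" are said of these compounds alone.

Compound 2 `COc1ccc(/C=C/C(=O)/C=C/c2ccc(OCc3cn(CCOc4cc(=O)oc5ccccc45)nn3)c(OC)c2)cc1OC` is the point of departure. Among the measured compounds shown here, in a functional assay on HCT-116 cells (Homo sapiens) for cytotoxicity, read by sulforhodamine B assay, with a stated time of 48 h (a lower number here means a stronger inhibitor, a higher number a weaker inhibitor), compound 2 gives 4710 nM, which puts it at the low end of the three numbers so far: compound 1 `COc1ccccc1/C=C/C(=O)/C=C/c1ccc(OCc2cn(CCOc3cc(=O)oc4ccccc34)nn2)c(OC)c1` gives 9490 nM and lies within the scatter of compound 2, while compound 3 `COc1ccc(/C=C/C(=O)/C=C/c2ccc(OCc3cn(CCCOc4cc(=O)oc5ccccc45)nn3)c(OC)c2)cc1OC` gives 11000 nM and lies beyond it. For the measured compounds named here, the one single-point step measured, a 2.0-fold lower number from compound 1 to compound 2 (0.30 log units; within the scatter), changed the aryl group on the double-bonded chain carbon and stayed within the scatter.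

Compound 4 `COc1cc(/C=C/C(=O)/C=C/c2ccco2)ccc1OCc1cn(CCOc2cc(=O)oc3ccccc23)nn1` alters compound 2 at that same place: furan-2-yl in place of 3,4-dimethoxyphenyl on a double-bonded chain carbon bound to a double-bonded chain carbon. Going by the values given here, the step from compound 1 to compound 2 is the only one that bears on this position, and it was small; no measured compound carries a furan-2-yl, so nothing shows how a five-membered ring behaves here. On that basis a step of no great size is expected, with a slight lean toward a higher number because compound 2 with its 3,4-dimethoxyphenyl gives 4710 nM and that group is the one removed.

Compound 4 is therefore estimated at 7000 nM, with a range from 2500 nM to 20000 nM, which is expected to mean a 1.5-fold higher number from compound 2 to compound 4 (0.17 log units; within the scatter).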

Compound 4, half-maximal inhibitory concentration: 9180 nM
Compound 4: middle estimate off by 1.3-fold (0.12 log units), on the low side; the measured number falls inside the stated range.
By their numbers in this assay, from the lowest: compounds 2, 4, 1 and 3 (each within the scatter of the next, the first and the last beyond it).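

In this assay, furan-2-yl on a double-bonded chain carbon bound to a double-bonded chain carbon gives a 1.9-fold higher number from compound 2 to compound 4 (0.29 log units; within the scatter), so going from 10 heavy atoms in 3,4-dimethoxyphenyl to 5 in a five-membered aromatic ring with 1 hetero atom leaves the number within the scatter. The comparison with the other aryl group gives a 1.0-fold lower number from compound 1 to compound 4 (0.01 log units; within the scatter), so this assay does not separate furan-2-yl, 2-methoxyphenyl and 3,4-dimethoxyphenyl at this place, and the earlier single step between two six-membered aromatic rings now extends to a five-membered one. Nothing measured accounts for why these three groups read so closely.

The compounds shown leave open whether any group at this place would carry the number beyond the scatter, such as an aromatic ring bearing an amine or a carboxylic acid, or a simple methyl in place of a ring. They also leave open whether furan-2-yl would read the same on the chain of compound 3, which gives 11000 nM with its 3,4-dimethoxyphenyl.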